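A Second Trifluoromethyl Enters the Amide Ring

The source may report more compounds than this note shows. Statements on the series, on what has been measured and on what is new or still open speak of the compounds shown alone.

In a functional assay on SN12C cells (Homo sapiens) for inhibition, read by sulforhodamine B assay, with a stated time of 48 h, tested at 10 uM (a lower number here means a stronger effect, a higher number a weaker effect of the compound at the concentration tested), compound 1 `COc1cc(Cl)cc(-c2nn(-c3cccc(NC(=O)Nc4ccc(Cl)c(C(F)(F)F)c4)c3)cc2-c2ccncc2)c1` gives 13.8%, while compound 2 `COc1cc(Cl)cc(-c2nn(-c3cccc(NC(=O)c4cccc(C(F)(F)F)c4)c3)cc2-c2ccncc2)c1` gives 65.9%, the higher of the two numbers. For the measured compounds named here, the only step seen so far, a number 52.1 percentage points higher from compound 1 to compound 2 (beyond the scatter), is large. Compound 3 `COc1cc(Cl)cc(-c2nn(-c3cccc(NC(=O)c4cc(C(F)(F)F)cc(C(F)(F)F)c4)c3)cc2-c2ccncc2)c1` differs from compound 2 by trifluoromethyl in place of hydrogen on an aromatic carbon. Going by the values given here, no measured step touches this change, and the single known step concerns a different part of the molecule, so no step beyond the scatter is expected in this assay. Compound 3 is therefore estimated at 60%, between 35% and 90%, which would mean an expected step of a number 5.9 percentage points lower from compound 2 to compound 3 (within the scatter).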

Compound 3, a percentage reported as activity, at one concentration (the size of the read-out at that concentration, not a potency): 69.8%
The estimate for compound 3 lay 9.8 percentage points below the measured number; measured number inside the range.
By their numbers in this assay, from the lowest: compound 1; then compounds 2 and 3 (each within the scatter of the next).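

The step of a number 3.9 percentage points higher from compound 2 to compound 3 (within the scatter) in this assay shows that this aromatic carbon, meta to a trifluoromethyl group, can carry a second trifluoromethyl instead of hydrogen without a readable change in the number. A group of 4 heavy atoms thus enters here and the result stays within ordinary repeat variation. No other measurement bears on this result. On these data alone, whether an amine, a carboxylic acid or a methoxy group on this same carbon would also leave the number in place remains open.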